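Ethoxy to (4-methoxyphenyl)amino on a carbonyl carbon

This account rests on a few compounds, and the source may have more. Where it says the series, first, only, none or still open, it means among the compounds named here.

Measured in a functional assay on HT-29 cells (Homo sapiens) for inhibition, read by MTT assay, with a stated time of 48 h; a lower number here means a stronger inhibitor, a higher number a weaker inhibitor
compound 1 `COc1ccc(-n2c(SCC(=O)c3ccc4ccccc4c3)nnc2-c2cc(OC)c(OC)c(OC)c2)cc1` gives 53400 nM
compound 2 `CCOC(=O)CSc1nnc(-c2cc(OC)c(OC)c(OC)c2)n1-c1ccc(OC)cc1` gives > 60000 nM as a limit

Compound 2 has only the limit of > 60000 nM in this assay, at which 1 of the 2 values shown sits, and no number. Compound 3 `COc1ccc(NC(=O)CSc2nnc(-c3cc(OC)c(OC)c(OC)c3)n2-c2ccc(OC)cc2)cc1` has (4-methoxyphenyl)amino in place of ethoxy on a carbonyl carbon and is not yet measured. Going by the values given here, the one measured step at this carbon is an at least 1.1-fold higher number from compound 1 to compound 2 (0.05 log units; that floor lies within the scatter) and it stays within the scatter. Compound 1, with its naphthalen-2-yl on the carbonyl carbon, gives 53400 nM and so only a small move towards a lower number is expected in this assay for the new aromatic group. The expected change is an at least 1.5-fold lower number from compound 2 to compound 3 (0.17 log units; that floor lies within the scatter) and it rests on that single step. The estimate for compound 3 is 40000 nM (expected range 10000 nM to 70000 nM).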

Compound 3, half-maximal inhibitory concentration: 45300 nM
Beside the measured number, compound 3's estimate is 1.1-fold (0.05 log units) below it; low and high end bracket the measured number.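

In this assay, the change of ethoxy to (4-methoxyphenyl)amino on this carbonyl carbon is an at least 1.3-fold lower number from compound 2 to compound 3 (0.12 log units; that floor lies within the scatter). Its true size cannot be read, as compound 2 carries a limit and not a number: the limit of > 60000 nM in this assay, at which 1 of the 3 values shown sits. Replacing naphthalen-2-yl with (4-methoxyphenyl)amino is a 1.2-fold lower number from compound 1 to compound 3 (0.07 log units; within the scatter), so these two aromatic groups, one joined directly and one through the amide nitrogen, cannot be told apart here.

Open, from the compounds shown here alone, is how a carboxylic acid or a morpholine amide at this carbonyl carbon would read. Also open, going by these compounds, is whether any change here moves the number beyond the scatter.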